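Working notes: cytotoxicity of compounds 1 to 4

A few compounds are considered here, and "the series" means these few. Any claim that something is new, unique, unknown or untested is made for them only; others in the source may bear on it.

Values in an ADME assay on L929 cells (Mus musculus) for cytotoxicity, read by resazurin assay, with a stated time of 72 h (on this read-out higher numbers stand for weaker inhibition and lower numbers for stronger inhibition), so far:
Compound 1 `OB1OCc2ccc(-n3cc(Sc4cccc(Cl)c4)c4ccccc43)cc21` gives > 10 ug/mL, a limit of the assay.
Compound 2 `CCNC(=O)c1cccn1-c1ccc2c(c1)B(O)OC2` gives > 10 ug/mL, a limit of the assay.
Compound 3 `CC(=O)c1ccn(-c2ccc3c(c2)B(O)OC3)c1` gives > 10 ug/mL, a limit of the assay.

Compound 3 therefore stands nowhere in particular on the numbers shown: its result is only a limit, and the two other values shown are limits as well. For the measured compounds named here, the series sits at the limit of > 10 ug/mL in this assay, at which 3 of the 3 values shown sit, so no ordering among the three is possible and no step between measured compounds can be stated.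

Compound 4 `CCCCCC(=O)c1ccn(-c2ccc3c(c2)B(O)OC3)c1` is the next member; it differs from compound 3 by butyl in place of hydrogen on a saturated chain carbon bound to a carbonyl carbon.

Going by the values given here, with no measured step to lean on, the expectation for this assay is a step that the limit leaves unreadable from compound 3 to compound 4, estimated as small, most likely none beyond the scatter, with the direction, if any, toward stronger inhibition. For compound 4 the expected value in this assay is 15 ug/mL, estimated to lie between 5 ug/mL and 40 ug/mL, with a fair chance that the assay again reports only a limit.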

Compound 4, half-maximal inhibitory concentration: > 10 ug/mL
Compound 4: only a limit was reported (the forecaster's own chance of this, stated with the estimate: 65%); the middle value is on the limit's open side.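

No new step can be read from compound 3 to compound 4, since both results are only limits: the limit of > 10 ug/mL in this assay, at which 4 of the 4 values shown sit.
The compounds shown leave open whether butyl in place of hydrogen alters cytotoxicity at all, and how far any of the four compounds lies from that limit.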